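This account rests on a few compounds, and the source may have more. Where it says the series, first, only, none or still open, it means among the compounds named here.

Compound 2 `CCC(C)CNC(=O)OCC1CN(C(=O)c2cc(OC)c(OC)c(OC)c2)CCN1C(=O)c1cc(OC)c(OC)c(OC)c1` carries a (2-methylbutyl)amino group on the carbonyl carbon of its side chain. In a functional assay (Oryctolagus cuniculus) for inhibition of platelet-activating factor receptor (Cavia porcellus) (on this read-out higher numbers stand for weaker inhibition and lower numbers for stronger inhibition), compound 2 gives 470 nM. Within the data shown here, only one other compound has been measured: compound 1 `CCCC(=O)OCC1CN(C(=O)c2cc(OC)c(OC)c(OC)c2)CCN1C(=O)c1cc(OC)c(OC)c(OC)c1`, which in this assay gives 420 nM. Among the measured compounds shown here, the sole step available, a 1.1-fold higher number from compound 1 to compound 2 (0.05 log units; within the scatter), shows that swapping the group on that carbonyl carbon left the read-out essentially unchanged, so compound 2 cannot be told apart from compound 1 on these numbers.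

Compound 3 `CCCCCN(CCCCC)C(=O)OCC1CN(C(=O)c2cc(OC)c(OC)c(OC)c2)CCN1C(=O)c1cc(OC)c(OC)c(OC)c1` is the next change at the same position: dipentylamino in place of (2-methylbutyl)amino on a carbonyl carbon. For the measured compounds named here, the one step that bears on this, a 1.1-fold higher number from compound 1 to compound 2 (0.05 log units; within the scatter), was within the scatter, so a further exchange at this carbonyl carbon is expected to give no step beyond the scatter, meaning a 1.0-fold lower number from compound 2 to compound 3 (0.02 log units; within the scatter). Compound 3 is therefore estimated at 450 nM, with a range from 200 nM to 1100 nM.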

Compound 3, half-maximal inhibitory concentration: 11400 nM
Compound 3: the middle estimate sits 25-fold (1.40 log units) below what was measured, and the stated range ends below it.
By their numbers in this assay, from the lowest: compounds 1 and 2 (each within the scatter of the next); then compound 3.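

The position is not indifferent after all. In this assay, inhibition weakens sharply on moving to dipentylamino, both from the (2-methylbutyl)amino group (a 24-fold higher number from compound 2 to compound 3 (1.38 log units; beyond the scatter)) and from the propyl group (a 27-fold higher number from compound 1 to compound 3 (1.43 log units; beyond the scatter)), although the earlier swap on this carbonyl carbon stayed within the scatter. Dipentylamino has more heavy atoms than (2-methylbutyl)amino and no hydrogen-bond donor, but nothing available here accounts for the loss.

The compounds shown leave open whether the loss goes with the second chain on the nitrogen, the length of the chains, or the missing hydrogen on that nitrogen. A pentylamino group, which keeps that hydrogen with one pentyl chain, and a dipropylamino group, which has two shorter chains, would begin to separate these possibilities.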